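A few compounds are considered here, and "the series" means these few. Any claim that something is new, unique, unknown or untested is made for them only; others in the source may bear on it.

Measured so far:
compound 1 `CC(C)C[C@H](N)c1cc(C(F)(F)F)ccc1N1CCN(C(=O)COc2cccc(Cl)c2)CC1`: 2600 nM
compound 2 `Cc1cc(CC(C)C(=O)N2CCN(c3ccc(C(F)(F)F)cc3[C@@H](N)CC(C)C)CC2)ccc1Cl`: 71 nM

For the measured compounds named here, in an assay on HEK293 cells for displacement of a labelled ligand from Melanocortin receptor 4 (Homo sapiens) (on this read-out lower numbers stand for stronger inhibition and higher numbers for weaker inhibition), compound 2 gives 71 nM, the lower of the two numbers; compound 1 gives 2600 nM, and the only measured step is a 37-fold lower number from compound 1 to compound 2 (1.56 log units; beyond the scatter). Compound 3 `COc1ccc(CC(C)C(=O)N2CCN(c3ccc(C(F)(F)F)cc3[C@@H](N)CC(C)C)CC2)cc1F` differs from compound 2 in one place: 3-fluoro-4-methoxyphenyl in place of 4-chloro-3-methylphenyl on a saturated chain carbon, two bonds along the chain from a carbonyl carbon. Going by the values given here, the measured step changed a different part of the molecule, so no measured step bears directly on this change. Compound 3 is therefore expected to land near compound 2, with an estimated step of a 2.1-fold higher number from compound 2 to compound 3 (0.32 log units; beyond the scatter). Compound 3 is estimated at 150 nM, within a range of 40 nM to 600 nM.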

Compound 3, inhibition constant: 200 nM
The estimate for compound 3 lay 1.3-fold (0.12 log units) below the measured number; the measured number falls inside the stated range.
By their numbers in this assay, from the lowest: compound 2; then compound 3; then compound 1.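

The change at this position, on a saturated chain carbon two bonds along the chain from a carbonyl carbon, gives a 2.8-fold higher number from compound 2 to compound 3 (0.45 log units; beyond the scatter) and so is a modest step, showing that the number responds to the choice of aryl group. The swap of 4-chloro-3-methylphenyl for 3-fluoro-4-methoxyphenyl does not cancel the larger change on the carbonyl carbon, since the (3-chlorophenoxy)methyl comparison still gives a 13-fold lower number from compound 1 to compound 3 (1.11 log units; beyond the scatter) and remains a large step. No measurement given here accounts for the difference between the two aryl groups. The compounds shown leave open how an unsubstituted phenyl or a pyridine ring would read at this position, and whether a single chlorine or methoxy substituent would be enough.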